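Swapping Trifluoromethyl for 1-Hydroxy-1-methylethyl in Compound 3

This account rests on a few compounds, and the source may have more. Where it says the series, first, only, none or still open, it means among the compounds named here.

Measured so far in an ADME assay on LLC-PK1 cells (Sus scrofa) for permeability, with a stated time of 3 h, tested at 1 uM; a higher number here means that the compound crosses the layer faster, a lower number that the compound crosses the layer more slowly:
- compound 1 `O=C(O)CNC(=O)c1c(O)c2c(n(Cc3ccc(C(F)(F)F)cc3)c1=O)COCC2`: 7.3 10^-6 cm/s
- compound 2 `N#Cc1ccc(Cn2c3c(c(O)c(C(=O)NCC(=O)O)c2=O)COCC3)c(F)c1`: "not determined" (no result reported)
- compound 3 `O=C(O)CNC(=O)c1c(O)c2c(n(Cc3ccc(C(F)(F)F)cc3)c1=O)COC2`: 4.2 10^-6 cm/s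

Among the measured compounds shown here, only two numbers are available, and they lie within the usual scatter of repeated measurements. Compound 3 with 4.2 10^-6 cm/s and compound 1 with 7.3 10^-6 cm/s therefore cannot be told apart in this assay. Compound 2 has no number, so it offers no guidance here.

The next molecule is compound 4 `CC(C)(O)c1ccc(Cn2c3c(c(O)c(C(=O)NCC(=O)O)c2=O)COC3)cc1`. It keeps the shared core of compound 3 and changes in one place, with 1-hydroxy-1-methylethyl in place of trifluoromethyl on an aromatic carbon. The group sits para to a large group, as the old one did.

For the measured compounds named here, no pair of measured compounds shows this swap, or any other single change, so the data give no direct size for the step. The expectation is therefore a judgement from the structural change alone, and it points toward a lower number than the 4.2 10^-6 cm/s of compound 3. The expected change in this assay is a 2.3-fold lower number from compound 3 to compound 4 (0.37 log units; beyond the scatter).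

For compound 4 the estimated value is 1.8 10^-6 cm/s, with an expected range of 0.6 10^-6 cm/s to 4.5 10^-6 cm/s.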

Compound 4, apparent permeability: < 1.5 10^-6 cm/s
Compound 4 gave a limit, no number; the forecaster's own chance of this, stated with the estimate: 10%; middle value at least 1.2-fold (0.07 log units) away from the limit.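

Among the compounds shown here, this is the first single change with a readable outcome in this assay: at this position on the aromatic ring, para to a large group, 1-hydroxy-1-methylethyl in place of trifluoromethyl gives an at least 2.8-fold lower number from compound 3 to compound 4 (0.44 log units; beyond the scatter). The group that enters carries 1 hydrogen-bond donor and 1 hydrogen-bond acceptor, while the group that leaves carries neither, so this position is not indifferent to the swap, even though a single change cannot show which feature of the new group matters. For compound 4 the assay gives a limit and not a number, so the step has a known minimum but no known full size: the limit of < 1.5 10^-6 cm/s in this assay, at which 1 of the 4 values shown sits.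

The compounds shown leave open whether the hydroxyl group itself matters, and a tert-butyl group at this place, which keeps the branched carbons without the oxygen, would help to separate the two, as would an amine. They also leave open whether the same swap on the core of compound 1 would give a step of similar size.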